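The source may report more compounds than this note shows. Statements on the series, on what has been measured and on what is new or still open speak of the compounds shown alone.

Compound 1 `COc1ccc(S(=O)(=O)N(CCO)CC(=O)NO)cc1` and compound 2 `COc1ccc(S(=O)(=O)N(CC(=O)NO)C[C@H](O)CO)cc1` share one core and have both been tested in an assay on isolated protein for inhibition of Matrilysin (Homo sapiens), read by fluorescence; on this read-out higher numbers stand for weaker inhibition and lower numbers for stronger inhibition. In this assay compound 1 gives 1500 nM, the lowest of the two numbers, and compound 2 gives 9000 nM. Within the data shown here, the only measured step, a 6.0-fold higher number from compound 1 to compound 2 (0.78 log units; beyond the scatter), concerns a change on the chain and not on the aromatic ring.

Compound 3 `O=C(CN(CCO)S(=O)(=O)c1ccc(F)cc1)NO` is yet to be measured. It differs from compound 1 by fluoro in place of methoxy on an aromatic carbon. Among the measured compounds shown here, no measured step touches this position, so the size and direction of the change in this assay can only be guessed. It seems fair to expect a movement toward weaker inhibition, but the measured compounds give no firm footing for how far. For compound 3 the estimate is 5000 nM, within a range from 1500 nM to 20000 nM, which would mean a step of a 3.3-fold higher number from compound 1 to compound 3 (0.52 log units; beyond the scatter).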

Compound 3, inhibition constant: 3000 nM
Compound 3: the middle estimate sits 1.7-fold (0.22 log units) above what was measured; the range from low to high includes it.
By their numbers in this assay, from the lowest: compounds 1 and 3 (each within the scatter of the next); then compound 2.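

In this assay, putting fluoro in place of methoxy on this aromatic carbon gives a 2.0-fold higher number from compound 1 to compound 3 (0.30 log units; within the scatter) and so stays inside the usual scatter of repeated measurements. Among these compounds, this is the first measured step at this position, and it shows that methoxy, with its two heavy atoms and one hydrogen-bond acceptor, can give way to fluoro, with one heavy atom and no acceptor, without a difference that can be told from noise, whereas the chain step a 6.0-fold higher number from compound 1 to compound 2 (0.78 log units; beyond the scatter) lies beyond the scatter. Nothing at hand offers a reason for this result.

Still open, on these data alone, is whether other groups on this carbon, such as an amine, a carboxylic acid or a longer butoxy chain, would give a number beyond the scatter. Also open, as far as these compounds go, is whether fluoro would give a similar result on the chain of compound 2.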